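Piperidinol to hydroxyethyl morpholine on the benzamide carbonyl

A few compounds are considered here, and "the series" means these few. Any claim that something is new, unique, unknown or untested is made for them only; others in the source may bear on it.

Measured compounds:
compound 1, `COc1cc(C(=O)N2CCC(O)C(C)C2)cc2nc(NCc3cccc(Cl)c3)oc12`: 84 nm/s
compound 2, `COc1cc(C(=O)N2CCC(O)C(C)C2)cc2nc(N[C@H](C)c3cccc(Cl)c3)oc12`: "not determined" (no result reported)

Within the data shown here, compound 1, `COc1cc(C(=O)N2CCC(O)C(C)C2)cc2nc(NCc3cccc(Cl)c3)oc12`, is the only compound with a number in an ADME assay on Caco-2 cells (Homo sapiens) for permeability, read by LC-MS, in the apical to basolateral direction, with a stated time of 2 h (on this read-out higher numbers stand for higher permeability and lower numbers for lower permeability), where compound 1 gives 84 nm/s. Among the measured compounds shown here, compound 2, `COc1cc(C(=O)N2CCC(O)C(C)C2)cc2nc(N[C@H](C)c3cccc(Cl)c3)oc12`, carries the same amide and the same core but a methyl-branched benzylic amine; in this assay compound 2 gives "not determined" (no result reported), so there is no value for compound 2 to stand on, and the one fixed point is compound 1.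

Compound 3, `COc1cc(C(=O)N2C[C@H](C)OC[C@@H]2CCO)cc2nc(N[C@H](C)c3cccc(Cl)c3)oc12`, differs from compound 2 only at the amide: 5-(2-hydroxyethyl)-2-methylmorpholin-4-yl in place of 4-hydroxy-3-methylpiperidin-1-yl on a carbonyl carbon. For the measured compounds named here, the change keeps one hydrogen-bond donor and adds one hydrogen-bond acceptor, and no comparable step exists among the measured compounds. From compound 1 as the only anchor at 84 nm/s, the expected step in this assay from compound 2 to compound 3 is none beyond the scatter, with a slight lean toward lower permeability.

Compound 3 is therefore estimated in this assay at 60 nm/s, with a range from 20 nm/s to 180 nm/s.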

Compound 3, apparent permeability: 101 nm/s
For compound 3 the middle estimate is 1.7-fold (0.23 log units) below the measured one, within the range that was stated.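

In this assay, among these compounds, compound 3 gives 101 nm/s, while compound 2 gives "not determined" (no result reported), so no step between compound 2 and compound 3 can be read. The compounds shown leave open how the exchange at the amide bears on this read-out, and nothing at hand offers an explanation for the value of compound 3.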